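Adding a chloro group to the phenyl ring of compound 3

A few compounds are considered here, and "the series" means these few. Any claim that something is new, unique, unknown or untested is made for them only; others in the source may bear on it.

In a functional assay on MCF7 cells (Homo sapiens) for antiproliferative activity, read by MTT assay, with a stated time of 72 h (on this read-out lower numbers stand for stronger inhibition and higher numbers for weaker inhibition), compound 1 (`CN(c1ccccc1)S(=O)(=O)C1CC2OC1C(c1ccc(NC(=O)CCCCCCC(=O)O)cc1)=C2c1ccc(O)cc1`) gives 63800 nM and compound 2 (`CN(c1cccc2ccccc12)S(=O)(=O)C1CC2OC1C(c1ccc(NC(=O)CCCCCCC(=O)O)cc1)=C2c1ccc(O)cc1`) gives 14000 nM while compound 3 (`CCN(c1ccccc1)S(=O)(=O)C1CC2OC1C(c1ccc(NC(=O)CCCCCCC(=O)O)cc1)=C2c1ccc(O)cc1`) gives 19100 nM on the same read-out. Compound 3 stands level with compound 2 (a 1.4-fold higher number from compound 2 to compound 3 (0.13 log units; within the scatter)) and below compound 1. Compound 4 (`CCN(c1ccccc1Cl)S(=O)(=O)C1CC2OC1C(c1ccc(NC(=O)CCCCCCC(=O)O)cc1)=C2c1ccc(O)cc1`) carries chloro in place of hydrogen on an aromatic carbon, ortho to a large group (chloro in place of hydrogen on an aromatic carbon). Two measured changes on the same side of the molecule come closest: naphthalen-1-yl in place of phenyl (a 4.6-fold lower number from compound 1 to compound 2 (0.66 log units; beyond the scatter)) and methyl in place of hydrogen on the chain (a 3.3-fold lower number from compound 1 to compound 3 (0.52 log units; beyond the scatter)). Neither adds a chloro group, so only a modest step to a lower number is expected (a 2.2-fold lower number from compound 3 to compound 4 (0.35 log units; beyond the scatter)) in this assay. For compound 4 the estimated value is 8500 nM (range 3500 nM to 20000 nM).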

Compound 4, half-maximal inhibitory concentration: 33300 nM
Compound 4: the middle estimate sits 3.9-fold (0.59 log units) below what was measured; measured number above the stated range.
By their numbers in this assay, from the lowest: compounds 2, 3, 4 and 1 (each within the scatter of the next, the first and the last beyond it).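

In this assay, chloro in place of hydrogen on this aromatic carbon, ortho to a large group, gives no step beyond the scatter: a 1.7-fold higher number from compound 3 to compound 4 (0.24 log units; within the scatter). Against methyl(naphthalen-1-yl)amino on the sulfonyl sulfur, the (2-chlorophenyl)(ethyl)amino group shows a 2.4-fold higher number from compound 2 to compound 4 (0.38 log units; beyond the scatter), while against methyl(phenyl)amino it shows a 1.9-fold lower number from compound 1 to compound 4 (0.28 log units; within the scatter). No measurement is available that would explain this result. The compounds shown leave open how fluoro or methoxy would read on this same carbon. They also leave open whether chloro on another carbon of this ring would read differently.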